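Second chloro on the anilide ring: from compound 1 to compound 4

This account rests on a few compounds, and the source may have more. Where it says the series, first, only, none or still open, it means among the compounds named here.

Measured so far in a functional assay on HEK293 cells for agonist activity at D(4) dopamine receptor (Homo sapiens), read by FLIPR; a higher number here means that more compound is needed for the effect, a lower number that less compound is needed:
compound 1, `O=C(CN1CCC(c2cccc[n+]2[O-])CC1)Nc1cccc(Cl)c1`, gives 62 nM
compound 2, `CC(C)Oc1cccc(NC(=O)CN2CCC(c3cccc[n+]3[O-])CC2)c1`, gives 555 nM
compound 3, `O=C(NCN1CCC(c2cccc[n+]2[O-])CC1)c1ccccc1`, gives 532 nM

Compound 1 stands at the lowest of the three numbers. Compound 3 sits a 9.0-fold higher number from compound 1 to compound 2 (0.95 log units; beyond the scatter) away in the other direction of the table, and the two values of compound 1 and compound 3 differ by a gap that lies beyond the scatter, as does the gap between compound 1 and compound 2.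

Compound 4, `O=C(CN1CCC(c2cccc[n+]2[O-])CC1)Nc1cc(Cl)cc(Cl)c1`, differs from compound 1 in one place: chloro in place of hydrogen on an aromatic carbon. For the measured compounds named here, the only measured step touching the same aromatic ring is the one from compound 1 to compound 2, where isopropoxy in place of chloro gave a 9.0-fold higher number from compound 1 to compound 2 (0.95 log units; beyond the scatter). Going by the values given here, no measured pair shows a second chloro entering while the first stays, so that step bears on the present one only loosely. A change that keeps the chloro of compound 1 and adds a second is expected to move this assay by less than the isopropoxy exchange did, and the account therefore expects for compound 4 a small rise or no step beyond the scatter, a 1.6-fold higher number from compound 1 to compound 4 (0.21 log units; within the scatter).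

The estimate for compound 4 is 100 nM, within 30 nM to 350 nM.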

Compound 4, half-maximal effective concentration: 160 nM
Estimate against measurement, compound 4: 1.6-fold (0.20 log units) below, within the range that was stated.
By their numbers in this assay, from the lowest: compound 1; then compound 4; then compounds 3 and 2 (each within the scatter of the next).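

In this assay, for the compounds shown here, the change from 3-chlorophenyl to 3,5-dichlorophenyl is the first measured case in which the chloro of compound 1 stays and a second group enters the ring, and it is not neutral (a 2.6-fold higher number from compound 1 to compound 4 (0.41 log units; beyond the scatter)). The hydrogen at this place, meta to a chloro group, therefore cannot be exchanged for chloro without a step beyond the scatter, and the direction matches that of the other measured change on this ring, isopropoxy in place of chloro (a 9.0-fold higher number from compound 1 to compound 2 (0.95 log units; beyond the scatter)). So both single changes to this ring that are shown here raise the number, one by replacing the chloro and one by adding a second, and no information at hand accounts for either step.

On these data alone, it remains open whether the rise belongs to chloro itself or to any group at this place, as a fluoro, a methyl, a methoxy or a nitrile there would show. Also open, as far as these compounds go, is whether chloro at this place would give the same step on a phenyl ring that lacks the first chloro.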